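Nitro sulfone benzamide series: varying the glycinamide tail

This account rests on a few compounds, and the source may have more. Where it says the series, first, only, none or still open, it means among the compounds named here.

The series is examined in an assay on isolated protein for inhibition of thyroid hormone receptor alpha (Homo sapiens), read by fluorescence polarization; on this read-out higher numbers stand for weaker inhibition and lower numbers for stronger inhibition. Compound 1 (`CN(Cc1cccc(F)c1)C(=O)CNC(=O)c1ccc(S(C)(=O)=O)c([N+](=O)[O-])c1`) carries the shared core on a glycinamide whose tail bears a fluorinated benzyl group; in this assay compound 1 returns only the limit > 60000 nM, not a number. Compound 2 (`CCCN(C(=O)CN(C)C(=O)c1ccc(S(C)(=O)=O)c([N+](=O)[O-])c1)c1ccccc1`) places a phenyl(propyl)amino group on the tail carbonyl; in this assay compound 2 likewise returns only the limit > 60000 nM, again not a number. For the measured compounds named here, compound 2 thus stands where every value so far stands, since (the limit of > 60000 nM in this assay, at which 2 of the 2 values shown sit), and no difference between the two measured compounds can be read from these limits.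

Compound 3 (`CN(CC(=O)N1CCc2ccccc2C1)C(=O)c1ccc(S(C)(=O)=O)c([N+](=O)[O-])c1`) is the next member: 1,2,3,4-tetrahydroisoquinolin-2-yl in place of phenyl(propyl)amino on a carbonyl carbon. Going by the values given here, neither measured compound gives a number, so no step within the set can guide the size of this change; both sit at the limit, and nothing in the set points to a gain. The expected step from compound 2 to compound 3 is therefore none beyond the scatter, a number no higher from compound 2 to compound 3 (the limit leaves the size open), in this assay. Compound 3 is estimated at 60000 nM in this assay, within 20000 nM to 200000 nM, with a limit rather than a number the most likely outcome.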

Compound 3, half-maximal inhibitory concentration: > 60000 nM
Compound 3 was reported as a limit (the forecaster's own chance of this, stated with the estimate: 80%); the middle value sits exactly at the limit.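

No step can be read from compound 2 to compound 3, as both are reported only as limits and not as numbers: the limit of > 60000 nM in this assay, at which 3 of the 3 values shown sit.

The compounds shown leave open whether any tail on the shared core gives a measurable number in this assay, and how 1,2,3,4-tetrahydroisoquinolin-2-yl compares with phenyl(propyl)amino on a carbonyl carbon.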